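Cytotoxicity Outlook for a Nitrophenyl Analogue

The compounds below may be only part of what the source reports. "The series", "measured", "known", "first", "only" and "open" are said of these compounds alone.

Compound 1 `N#Cc1c(-c2ccccc2Cl)c(C#N)c(=O)n(/N=C/c2cn(-c3ccccc3)nc2-c2ccccc2)c1N` was tested in an ADME assay on HeLa cells (Homo sapiens) for cytotoxicity, read by MTT assay; on this read-out lower numbers stand for stronger inhibition and higher numbers for weaker inhibition. In this assay compound 1 reaches only the assay limit of > 200 ug/mL, not a number. Compound 2 `COc1cc(-c2c(C#N)c(N)n(/N=C/c3cn(-c4ccccc4)nc3-c3ccccc3)c(=O)c2C#N)cc(OC)c1OC` carries a 3,4,5-trimethoxyphenyl in place of the 2-chlorophenyl on an aromatic carbon. In this assay compound 2 likewise gives only the limit of > 200 ug/mL. The step that the two limits leave unreadable from compound 1 to compound 2 therefore stays unreadable, and what the two measurements share is the limit of > 200 ug/mL in this assay, at which 2 of the 2 values shown sit. Compound 3 `N#Cc1c(-c2ccccc2[N+](=O)[O-])c(C#N)c(=O)n(/N=C/c2cn(-c3ccccc3)nc2-c2ccccc2)c1N` differs from compound 2 by 2-nitrophenyl in place of 3,4,5-trimethoxyphenyl on an aromatic carbon. Within the data shown here, the only measured step bears on the same position and the same kind of exchange of the aryl group, yet its size is not readable, so no shift beyond the scatter is expected. For compound 3 the expected result is 250 ug/mL, with a range from 100 ug/mL to 600 ug/mL. The step expected is a step that the limit leaves unreadable from compound 2 to compound 3.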

Compound 3, half-maximal inhibitory concentration: > 200 ug/mL
Compound 3: a limit, no number (the forecaster's own chance of this, stated with the estimate: 75%); the middle value lies beyond the limit too.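

Among these compounds, compound 3 joins compound 1 and compound 2 at a limit rather than a number, so no step among the three can be read: the limit of > 200 ug/mL in this assay, at which 3 of the 3 values shown sit. The compounds shown leave open whether any aryl group on the shared core gives a measurable value in this assay.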